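The source may hold more compounds than are shown below. What is called first, only, known or untested is meant among the compounds shown, and "the series" means these compounds.

Compound 1 `COc1cc(-c2cc(/C=C/C(=O)c3ccc(N)cc3)[nH]n2)cc(OC)c1OC` was tested in a functional assay on OVCAR-3 cells (Homo sapiens) for inhibition, read by sulforhodamine B assay, with a stated time of 48 h (a lower number here means a stronger inhibitor of growth, a higher number a weaker inhibitor of growth), where compound 1 gives 3370 nM. Compound 2 `COc1ccc(-c2cc(/C=C/C(=O)c3ccc(N)cc3)[nH]n2)cc1OC` differs from compound 1 in one place (hydrogen in place of methoxy on an aromatic carbon), and in this assay compound 2 gives 4190 nM; the measured step of a 1.2-fold higher number from compound 1 to compound 2 (0.09 log units; within the scatter) is a small one. Compound 3 `COc1cc(C(=O)/C=C/c2cc(-c3cc(OC)c(OC)c(OC)c3)n[nH]2)cc(OC)c1OC` carries the same kinds of groups on a different core, and the difference between the two cores is not broken down here. In this assay compound 3 gives 3180 nM, a number close to those of compound 1 and compound 2. Compound 4 `COc1ccc(-c2cc(/C=C/C(=O)c3cc(OC)c(OC)c(OC)c3)[nH]n2)cc1OC` has not yet been measured. It differs from compound 3 in one place (hydrogen in place of methoxy on an aromatic carbon), and the surroundings of that place match those of the change from compound 1 to compound 2 word for word, so the same change is made twice among these compounds. Because the measured step of a 1.2-fold higher number from compound 1 to compound 2 (0.09 log units; within the scatter) stays within the usual scatter, the step expected here is of similar size, a 1.2-fold higher number from compound 3 to compound 4 (0.08 log units; within the scatter). On that basis compound 4 is estimated to give 3800 nM in this assay, most likely between 1600 nM and 9000 nM.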

Compound 4, concentration for total growth inhibition: 3150 nM
Compound 4: middle estimate off by 1.2-fold (0.08 log units), on the high side; measured number inside the range.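

Putting hydrogen in place of this methoxy group gives a 1.0-fold lower number from compound 3 to compound 4 (0.00 log units; within the scatter) in this assay and so makes no readable difference on this core. Set beside the earlier step, the change behaves alike on the two cores: the same change on two cores in this assay, a 1.2-fold higher number (0.09 log units; within the scatter) from compound 1 to compound 2 and a 1.0-fold lower number (0.00 log units; within the scatter) from compound 3 to compound 4, 1.3-fold (0.10 log units) apart, within the scatter of two such steps. This supports carrying the change between these two cores only in a narrow sense, as both steps are too small to read as real effects, so the agreement does not show that a change with a large effect would carry over in the same way, and two pairs of compounds make no rule for the whole series.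

The compounds shown hold only methoxy or hydrogen at this place, so what a hydroxyl group, a fluorine atom, an amine or a longer chain such as ethoxy would do there remains open. Whether the swap would behave the same way on a third core, or in cells other than these, is open as well.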